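This account rests on a few compounds, and the source may have more. Where it says the series, first, only, none or still open, it means among the compounds named here.

Measured compounds in an ADME assay on Raji cells (Homo sapiens) for cytotoxicity, read by CellTiter-Glo and resazurin assay, with a stated time of 72 h; a lower number here means that less compound is needed, a higher number that more compound is needed for the effect:
- compound 1, `CC(C)N(Cc1cccc(OCCCCCC(=O)O)c1)C(=O)c1ccccc1`: > 26000 nM, a limit of the assay
- compound 2, `CC(=O)Nc1cccc(-c2ccc(C(=O)N(Cc3cccc(OCCCCCC(=O)O)c3)C(C)C)cc2)c1`: > 26000 nM, a limit of the assay
- compound 3, `COc1cccc(-c2ccc(C(=O)N(Cc3cccc(OCCCCCC(=O)O)c3)C(C)C)cc2)c1`: > 20900 nM, a limit of the assay

Within the data shown here, compound 1 stands only at a limit in this assay, and the two other values shown are limits as well, so no compound has yet given a number. Compound 4, `CC(C)N(Cc1cccc(OCCCCCC(=O)O)c1)C(=O)c1ccc(-c2ccc3[nH]ccc3c2)cc1`, differs from compound 1 by 1H-indol-5-yl in place of hydrogen on an aromatic carbon. The steps measured so far are a step that the two limits leave unreadable from compound 1 to compound 2 and a step that the two limits leave unreadable from compound 1 to compound 3, both of which add an aryl group at the same aromatic carbon, and a step that the two limits leave unreadable from compound 2 to compound 3; none of them has a readable size, since the values sit at the limit of > 26000 nM in this assay, at which 2 of the 3 values shown sit, and at the limit of > 20900 nM in this assay, at which 1 of the 3 values shown sits. There is therefore no basis for expecting a step beyond the scatter in either direction, and the most likely outcome for compound 4 is another limit. Compound 4 is estimated at 26000 nM, with a range from 8000 nM to 80000 nM, which means an expected step of a number no higher from compound 1 to compound 4 (the limit leaves the size open).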

Compound 4, half-maximal effective concentration: > 26000 nM
Compound 4: a limit, no number (the forecaster's own chance of this, stated with the estimate: 80%); the middle value lies on the limit itself.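

In this assay compound 4 gives > 26000 nM, a limit of the assay. The steps to compound 4 from compound 1, compound 2 and compound 3 therefore cannot be read. The compounds shown leave open whether any aryl group on the shared core changes the half-maximal effective concentration at all.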